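Chloro to Bromo: a Halogen Swap in Receptor Binding

The source may report more compounds than this note shows. Statements on the series, on what has been measured and on what is new or still open speak of the compounds shown alone.

Compound 1, `CCCc1cc(N)c2cc(NC(=O)/C=C/c3ccc(Cl)cc3)ccc2n1`: 6 nM
Compound 2, `CCCc1cc(N2CCCC2)c2cc(NC(=O)/C=C/c3ccc(C(F)(F)F)cc3)ccc2n1`: 17 nM

Among the compounds with values here, in an assay on isolated protein for displacement of a labelled ligand from melanin-concentrating hormone receptor 1 (Homo sapiens) (on this read-out lower numbers stand for stronger inhibition and higher numbers for weaker inhibition), compound 1 gives 6 nM, the lowest of the two numbers measured so far. Compound 2 gives 17 nM, a higher number that lies beyond the usual scatter. Compound 3, `CCCc1cc(N)c2cc(NC(=O)/C=C/c3ccc(Br)cc3)ccc2n1`, differs from compound 1 by bromo in place of chloro on an aromatic carbon. Within the data shown here, no measured pair shows this change, so the step is expected to be small, with no clear direction, and to stay within the scatter: no change at the digits printed from compound 1 to compound 3 (within the scatter). Compound 3 is therefore estimated at 6 nM, in a range from 3 nM to 14 nM.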

Compound 3, half-maximal inhibitory concentration: 4 nM
Compound 3: the middle estimate sits 1.5-fold (0.18 log units) above what was measured, within the range that was stated.
By their numbers in this assay, from the lowest: compounds 3 and 1 (each within the scatter of the next); then compound 2.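

Bromo in place of chloro on the aromatic carbon gives a 1.5-fold lower number from compound 1 to compound 3 (0.18 log units; within the scatter) in this assay, so this assay does not tell these two halogens apart at this position. Compounds 1 and 2 differ in more than one place and could not show this single change. Nothing measured here bears on the reason for this result. Still open, on these data alone, is how the number responds to a smaller halogen such as fluoro at this position, or to a group of another kind, such as an amine or a carboxylic acid.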